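Diaryl thiourea series: aryl swap on the thiourea nitrogen

The source may report more compounds than this note shows. Statements on the series, on what has been measured and on what is new or still open speak of the compounds shown alone.

Compound 1 `CNC(=O)c1ccc(Oc2cccc(NC(=S)Nc3ccc(F)c(C(F)(F)F)c3)c2)nc1` gives 7950 nM in a functional assay on PC-3 cells (Homo sapiens) for antiproliferative activity, read by MTT assay; on this read-out higher numbers stand for weaker inhibition and lower numbers for stronger inhibition. Among the measured compounds shown here, compound 2 `CNC(=O)c1ccc(Oc2cccc(NC(=S)Nc3ccc(Cl)cc3Cl)c2)nc1` gives 19300 nM in this assay, the highest of the two numbers, with compound 1 as its only neighbour. Compound 3 `CNC(=O)c1ccc(Oc2cccc(NC(=S)Nc3ccc(F)c(Cl)c3)c2)nc1` awaits measurement in this assay; its change from compound 2 is 3-chloro-4-fluorophenyl in place of 2,4-dichlorophenyl on an amide-type nitrogen. For the measured compounds named here, no measured step of this kind exists, so the expectation rests on the pair alone: a modest move to a lower number is expected, because compound 1 gives 7950 nM. The step is expected as a 2.1-fold lower number from compound 2 to compound 3 (0.33 log units; beyond the scatter). Compound 3 is estimated at 9000 nM, range 3000 nM to 27000 nM.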

Compound 3, half-maximal inhibitory concentration: 18400 nM
The estimate for compound 3 lay 2.0-fold (0.31 log units) below the measured number; the measured number falls inside the stated range.
By their numbers in this assay, from the lowest: compound 1; then compounds 3 and 2 (each within the scatter of the next).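

In this assay, 3-chloro-4-fluorophenyl in place of 2,4-dichlorophenyl on an amide-type nitrogen gives (a 1.0-fold lower number from compound 2 to compound 3 (0.02 log units; within the scatter)), so this read-out does not separate these two aryl groups. Chloro in place of trifluoromethyl on an aromatic carbon gives (a 2.3-fold higher number from compound 1 to compound 3 (0.36 log units; beyond the scatter)), the first single-place step in the series beyond the scatter. No measurement bears on the reason for either step.

Open, from the compounds shown here alone, is how a nitrile or methoxy group on that same aromatic carbon would compare with chloro and trifluoromethyl. Also open, going by these compounds, is how an unsubstituted phenyl on the amide-type nitrogen would read against these halogenated aryl groups.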